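The source may hold more compounds than are shown below. What is called first, only, known or untested is meant among the compounds shown, and "the series" means these compounds.

Measured so far:
compound 1, `CCOC(=O)C1=C(Nc2ccccc2)S/C(=C\c2ccc(O)c(O)c2)C1=O`, 30.7%
compound 2, `CCOC(=O)C1=C(Nc2ccccc2)S/C(=C\c2ccc(OC)cc2)C1=O`, 17.5%
compound 3, `CCOC(=O)C1=C(Nc2ccccc2)S/C(=C\c2ccc(C(=O)O)cc2)C1=O`, 11.6%

In a functional assay on A549 cells (Homo sapiens) for inhibition, read by MTT assay, with a stated time of 72 h, tested at 10 uM (on this read-out higher numbers stand for more inhibition at the one concentration tested (going by the name of the read-out) and lower numbers for less inhibition), compound 3 stands lowest of the three numbers. Its nearest neighbour is compound 2, and the step of a number 5.9 percentage points lower from compound 2 to compound 3 (within the scatter) stays within the scatter, so the two are not told apart. The step of a number 19.1 percentage points lower from compound 1 to compound 3 (beyond the scatter) is beyond the scatter, as is a number 13.2 percentage points lower from compound 1 to compound 2 (beyond the scatter).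

Compound 4, `CCOC(=O)C1=C(Nc2ccccc2)S/C(=C\c2cc[nH]c2)C1=O`, is not yet measured. It differs from compound 3 at the same place where the three measured compounds differ among themselves: 1H-pyrrol-3-yl in place of 4-carboxyphenyl on a double-bonded chain carbon bound to a double-bonded ring carbon.

All measured steps bear on this position. Both exchanges of the 3,4-dihydroxyphenyl group lowered the number modestly, while the exchange of carboxy for methoxy moved it within the scatter only. The new group carries one hydrogen-bond donor, which the 4-carboxyphenyl group also has, so no large shift is expected; a step of a number 5.4 percentage points higher from compound 3 to compound 4 (within the scatter) from compound 3 to compound 4 is estimated, within or barely beyond the scatter. For compound 4 the expected value in this assay is 17%, with a range from 4% to 33%.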

Compound 4, a percentage reported as inhibition, at one concentration (the size of the read-out at that concentration, not a potency): < 10%
Compound 4: only a limit was reported (the forecaster's own chance of this, stated with the estimate: 5%); middle value at least 7 percentage points from the limit.
By their numbers in this assay, from the lowest: compounds 3 and 2 (each within the scatter of the next); then compound 1. At a limit, below all of these: compound 4.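

In this assay compound 4 is reported only as a limit of the assay, not as a number: the limit of < 10% in this assay, at which 1 of the 4 values shown sits.

The five-membered 1H-pyrrol-3-yl ring at this place adds nothing over the six-membered groups, and the step of a number at least 20.7 percentage points lower from compound 1 to compound 4 (beyond the scatter) leaves the 3,4-dihydroxyphenyl group clearly ahead of this group as well. The steps of a number at least 1.6 percentage points lower from compound 3 to compound 4 (that floor lies within the scatter) and a number at least 7.5 percentage points lower from compound 2 to compound 4 (that floor lies within the scatter) have floors that do not separate 1H-pyrrol-3-yl from 4-carboxyphenyl or 4-methoxyphenyl, so the shared hydrogen-bond donor count of 4-carboxyphenyl and 1H-pyrrol-3-yl brings no visible gain.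

As far as these compounds go, the true size of the number for compound 4 stays open, and with it the order among compound 2, compound 3 and compound 4. Also open, from the compounds shown here alone, is whether a phenyl group carrying a single hydroxy group or an amine would hold the number of compound 1.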